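A Formyl Swapped for a Hydroxymethyl: Expecting Little Movement

The compounds below may be only part of what the source reports. "The series", "measured", "known", "first", "only" and "open" are said of these compounds alone.

Compound 2, `CCOc1ccc(Cl)cc1-c1cc(N)nc(Nc2ccc(C=O)cc2)c1`, is one of two measured members of a small set of compounds that share one core. In an assay on Sf9 cells for inhibition of 1-acyl-sn-glycerol-3-phosphate acyltransferase beta (Homo sapiens) (a lower number here means a stronger inhibitor, a higher number a weaker inhibitor), compound 2 gives 50 nM. Its closest measured relative is compound 1, `CCOc1ccc(Cl)cc1-c1cc(N)nc(Nc2ccc(Cl)cc2)c1`, which in this assay gives 50 nM; the step of no change at the digits printed from compound 1 to compound 2 (within the scatter) shows that exchanging one group for another at that aromatic carbon left the read-out where it was. Compound 3, `CCOc1ccc(Cl)cc1-c1cc(N)nc(Nc2ccc(CO)cc2)c1`, has not yet been measured. It differs from compound 2 in a single place: hydroxymethyl in place of formyl on an aromatic carbon. Within the data shown here, only one measured step bears on this change, the one leading from compound 1 to compound 2, and it was flat. That step exchanged a different pair of groups at the same aromatic carbon, so it speaks for how forgiving that position has been so far rather than for the hydroxymethyl itself. The expectation is therefore a step of about a 1.2-fold higher number from compound 2 to compound 3 (0.08 log units; within the scatter) in this assay, meaning no change beyond the scatter. Compound 3 is accordingly estimated at 60 nM, with a range from 25 nM to 150 nM.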

Compound 3, half-maximal inhibitory concentration: 99 nM
Estimate against measurement, compound 3: 1.7-fold (0.22 log units) below; low and high end bracket the measured number.
By their numbers in this assay, from the lowest: compounds 1, 2 and 3 (each within the scatter of the next).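

In this assay, putting hydroxymethyl in place of formyl gives a 2.0-fold higher number from compound 2 to compound 3 (0.30 log units; within the scatter), and putting it in place of chloro gives a 2.0-fold higher number from compound 1 to compound 3 (0.30 log units; within the scatter), so all three groups at this aromatic carbon, para to a large group, now read alike within the scatter. This change adds a hydrogen-bond donor and removes the double bond outside the aromatic rings, a different kind of difference from the one between chloro and formyl, yet neither difference carries the read-out beyond the scatter, which widens the earlier picture of a forgiving position from one exchange of groups to three compounds. Nothing at hand explains why these groups read alike.

Going by these compounds, what remains open is where that tolerance ends: a carboxylic acid, an amine or a longer chain such as hydroxyethyl at this same carbon could still move the number beyond the scatter. The three compounds also share the rest of the core unchanged, so they cannot tell whether this position stays as forgiving when the ethoxy group or the amine on the core is replaced.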